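Amide Variation on a Shared Core Where Every Value Is a Limit

The compounds below may be only part of what the source reports. "The series", "measured", "known", "first", "only" and "open" are said of these compounds alone.

Compound 1 `Cc1nc(C(=O)Nc2ccc(Cl)c(-c3nnc4c(Cl)cccn34)c2)cs1` carries a (2-methyl-1,3-thiazol-4-yl)carbonyl on the amide-type nitrogen of the shared core. In a functional assay on MCF7 cells (Homo sapiens) for antiproliferative activity, read by MTT assay, with a stated time of 72 h (on this read-out lower numbers stand for stronger inhibition and higher numbers for weaker inhibition), compound 1 gives only a limit, > 100000 nM. Compound 2 `Cc1cc(Cl)ccc1C(=O)Nc1ccc(Cl)c(-c2nnc3c(Cl)cccn23)c1` has 4-chloro-2-methylphenyl in place of 2-methyl-1,3-thiazol-4-yl on the carbonyl carbon, and in this assay compound 2 also gives only a limit, > 100000 nM. Compound 3 `O=C(Nc1ccc(Cl)c(-c2nnc3c(Cl)cccn23)c1)c1ccon1` carries 1,2-oxazol-3-yl on that carbonyl carbon, and in this assay compound 3 gives only a limit as well, > 100000 nM. Because (the limit of > 100000 nM in this assay, at which 3 of the 3 values shown sit), the three steps among these compounds cannot be sized: a step that the two limits leave unreadable from compound 1 to compound 2, a step that the two limits leave unreadable from compound 1 to compound 3 and a step that the two limits leave unreadable from compound 2 to compound 3 are all unreadable.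

Compound 4 `O=C(Nc1ccc(Cl)c(-c2nnc3c(Cl)cccn23)c1)c1cccnc1Cl` is the next member of the series. Its difference from compound 1 is 2-chloropyridin-3-yl in place of 2-methyl-1,3-thiazol-4-yl on a carbonyl carbon. For the measured compounds named here, the only steps that bear on it are the three acyl exchanges above, and none of them yields a readable size. In this assay compound 4 is therefore expected to sit at the same limit as its three relatives, estimated at 100000 nM within a range from 30000 nM to 300000 nM. The step of a number no higher from compound 1 to compound 4 (the limit leaves the size open) is expected to be none beyond the scatter.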

Compound 4, half-maximal inhibitory concentration: > 100000 nM
Compound 4 was reported as a limit; the forecaster's own chance of this, stated with the estimate: 80%; the middle value lies on the limit itself.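

In this assay compound 4 also gives only a limit, > 100000 nM. The steps joining compound 4 to compound 1, compound 2 and compound 3 cannot be read, because all four compounds stop at the same point: the limit of > 100000 nM in this assay, at which 4 of the 4 values shown sit.

The compounds shown leave open whether any group on that carbonyl carbon of the shared core gives a measurable value in this assay, and how these four compounds rank.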